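Series notes: propyl in place of pentyloxy on compound 2

This account rests on a few compounds, and the source may have more. Where it says the series, first, only, none or still open, it means among the compounds named here.

Measured so far in a functional assay (spleen, spleen) for activation, with Mus musculus as the target; a lower number here means that less compound is needed, a higher number that more compound is needed for the effect:
- compound 1, `CCSc1nc(N)c2nc(O)n(Cc3ccccc3)c2n1`: 0.1 uM
- compound 2, `CCCCCOc1nc(N)c2nc(O)n(Cc3ccccc3)c2n1`: 0.01 uM

Within the data shown here, compound 2 stands at the lowest of the two numbers; the only other compound, compound 1, sits at a higher number, and the single measured step, a 10-fold lower number from compound 1 to compound 2 (1.00 log units; beyond the scatter), lies beyond the scatter. Compound 3, `CCCc1nc(N)c2nc(O)n(Cc3ccccc3)c2n1`, differs from compound 2 in one place: propyl in place of pentyloxy on an aromatic carbon. Among the measured compounds shown here, only the step from compound 1 to compound 2 bears on this change, since it is the only one that altered this aromatic carbon: putting pentyloxy in place of ethylsulfanyl there gave a modest step to a lower number. The present change takes pentyloxy away again and puts in a shorter group without an acceptor, so a step back toward the number of compound 1 is expected, in the direction of a higher number and beyond the scatter. For compound 3 in this assay the expected value is 0.1 uM, with a range from 0.03 uM to 0.5 uM, meaning an expected step of a 10-fold higher number from compound 2 to compound 3 (1.00 log units; beyond the scatter).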

Compound 3, minimum effective concentration: 1 uM
For compound 3 the middle estimate is 10-fold (1.00 log units) below the measured one, and the stated range ends below it.
By their numbers in this assay, from the lowest: compound 2; then compound 1; then compound 3.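

In this assay, the aromatic carbon between two ring nitrogen atoms proves highly sensitive to the group it carries, with a 100-fold higher number from compound 2 to compound 3 (2.00 log units; beyond the scatter) when propyl replaces pentyloxy. The change does more than reverse the earlier gain, as propyl also falls short of ethylsulfanyl, with a 10-fold higher number from compound 1 to compound 3 (1.00 log units; beyond the scatter). Across these three compounds, the groups attached through oxygen or sulfur both give lower numbers than propyl, attached through carbon, although propyl is the only carbon-attached example.

The compounds shown do not separate chain length from the attaching atom, a question that pentyl or ethoxy at this carbon would address, and an amine there would test a nitrogen attachment. No measurement available here accounts for the size of these steps.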